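Swapping one aromatic group on a shared core

This account rests on a few compounds, and the source may have more. Where it says the series, first, only, none or still open, it means among the compounds named here.

Measured in an ADME assay (liver) for metabolic stability, with Liver microsome (Homo sapiens) as the target, using microsomes and NADPH, with a stated time of 30 min, tested at 1 uM; a higher number here means faster removal of the compound, a lower number slower removal
Compound 1 `Cc1csc(-c2cc(C(O)(C(F)(F)F)C(F)(F)F)cnc2N2CCN(S(=O)(=O)c3ccc(N)nc3)CC2)c1` gives 29 mL.min-1.g-1
Compound 2 `Cc1nc2cc(-c3cc(C(O)(C(F)(F)F)C(F)(F)F)cnc3N3CCN(S(=O)(=O)c4ccc(N)nc4)CC3)ccc2o1` gives < 14 mL.min-1.g-1

Compound 2 gives < 14 mL.min-1.g-1 in this assay and that is a limit of the assay. Compound 3 `Nc1ccc(S(=O)(=O)N2CCN(c3ncc(C(O)(C(F)(F)F)C(F)(F)F)cc3-c3ccc4[nH]ncc4c3)CC2)cn1` carries 1H-indazol-5-yl in place of 2-methyl-1,3-benzoxazol-5-yl on an aromatic carbon. Within the data shown here, the one measured step at this place, an at least 2.0-fold lower number from compound 1 to compound 2 (0.31 log units; beyond the scatter), exchanged a different pair of groups, so its size carries over only loosely. Little movement is therefore expected, any of it upward, with the expected step being an at least 1.0-fold higher number from compound 2 to compound 3 (0.02 log units; that floor lies within the scatter) in this comparison. For compound 3 the estimated value in this assay is 15 mL.min-1.g-1 (range 9 mL.min-1.g-1 to 32 mL.min-1.g-1).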

Compound 3, intrinsic clearance in microsomes: 27 mL.min-1.g-1
Beside the measured number, compound 3's estimate is 1.8-fold (0.26 log units) below it, within the range that was stated.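

In this assay, 1H-indazol-5-yl at this position gives an at least 1.9-fold higher number from compound 2 to compound 3 (0.28 log units; that floor lies within the scatter), so the lower number of compound 2 is not shown to extend to a second group with a five-membered and a six-membered aromatic ring. Against the 4-methylthiophen-2-yl group, the same position gives a 1.1-fold lower number from compound 1 to compound 3 (0.03 log units; within the scatter), which places two groups with different ring counts within the scatter of each other. The first step can be read only as a floor because compound 2 stands at a limit of the assay: the limit of < 14 mL.min-1.g-1 in this assay, at which 1 of the 3 values shown sits.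

Open, as far as these compounds go, is whether the hydrogen-bond donor of 1H-indazol-5-yl goes with this number, and how a 1-methylindazol-5-yl group would read here.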